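This account rests on a few compounds, and the source may have more. Where it says the series, first, only, none or still open, it means among the compounds named here.

Measured so far in a functional assay on HT-1080 cells (Homo sapiens), read by transwell migration, with a stated time of 24 h, tested at 10 uM; on this read-out lower numbers stand for a stronger effect and higher numbers for a weaker effect at the one concentration tested:
compound 1 `CC(=O)OCc1ccc2oc(=O)c(C(=O)Sc3cccc(Cl)c3)cc2c1` gives 61.9%
compound 2 `O=C(Oc1cccc(Cl)c1)c1cc2cc(CCl)ccc2oc1=O` gives 67%

Compound 2 holds the higher of the two numbers measured in this assay, but its nearest neighbour, compound 1, sits only slightly lower, and that gap lies within the scatter of repeated measurements, so the two compounds are not told apart by these data. Compound 3 `Cc1ccc2oc(=O)c(C(=O)Oc3cccc(Cl)c3)cc2c1` has not yet been measured. It differs from compound 2 in one place: hydrogen in place of chloro on a saturated chain carbon bound to an aromatic carbon. For the measured compounds named here, no pair of measured compounds covers this kind of change, so nothing measured here says which way the number will move, or whether it will move at all. The expected step from compound 2 to compound 3 is therefore a number 2 percentage points lower from compound 2 to compound 3 (within the scatter), meaning no shift beyond the scatter. Compound 3 is estimated to give 65% in this assay, with a range from 45% to 85%.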

Compound 3, a percentage reported as activity, at one concentration (the size of the read-out at that concentration, not a potency): 27.6%
Compound 3: middle estimate off by 37.4 percentage points, on the high side; measured number outside the range, below it.
By their numbers in this assay, from the lowest: compound 3; then compounds 1 and 2 (each within the scatter of the next).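

Going from chloromethyl to methyl on the saturated chain carbon bound to an aromatic carbon changes the read-out in this assay by a number 39.4 percentage points lower from compound 2 to compound 3 (beyond the scatter). Since lower numbers stand for a stronger effect, this place on the molecule is clearly sensitive to change, and the chlorine is not required for the effect at the one concentration tested: the smaller methyl group, with hydrogen in place of chloro, does better here. Nothing in the data shown explains why removing this one atom matters so much.

From the compounds shown here alone, it remains open whether methyl is special or whether other groups at this place, such as an amine, a carboxylic acid or a longer chain like propyl, would keep the stronger effect. A single concentration also leaves the potency of compound 3 unknown.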